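Working notes: from compound 1 to compound 3

A few compounds are considered here, and "the series" means these few. Any claim that something is new, unique, unknown or untested is made for them only; others in the source may bear on it.

Measured so far in a physicochemical assay for solubility, using the shake flask method, in phosphate buffer, with a stated time of 24 h, at pH 6.8; a lower number here means a less soluble compound, a higher number a more soluble compound
- compound 1 `COc1cc(/C=C/C(=O)/C=C(/C=C/c2ccc(O)c(OC)c2)NCCCO)ccc1O` gives 56300 nM
- compound 2 `O=C(/C=C(/C=C/c1ccc(O)cc1)NCCO)/C=C/c1ccc(O)cc1` gives 37900 nM

Within the data shown here, the values of compound 1 and compound 2 lie within the scatter of each other, so the two cannot be ranked and compound 1 stands level with the only other measured compound. The next compound to be measured is compound 3 (`COCCCNC(=C\C(=O)/C=C/c1ccc(O)c(OC)c1)/C=C/c1ccc(O)c(OC)c1`). It differs from compound 1 in one place (methyl in place of hydrogen on an oxygen on a saturated carbon): methyl in place of hydrogen on an oxygen on a saturated carbon, which reads as hydroxy to methoxy.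

Among the measured compounds shown here, no pair of measured compounds shows a step in one place, so this series offers no direct precedent for the change. For the measured compounds named here, the only anchor is the value of compound 1 (56300 nM). A small downward step is expected in this assay, possibly none beyond the scatter, and it is estimated as a 1.6-fold lower number from compound 1 to compound 3 (0.21 log units; within the scatter). The range is kept wide because the evidence is so thin.

The expected value for compound 3 is 35000 nM (estimated range 12000 nM to 90000 nM).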

Compound 3, solubility: 9660 nM
The estimate for compound 3 lay 3.6-fold (0.56 log units) above the measured number; measured number below the stated range.
By their numbers in this assay, from the lowest: compound 3; then compounds 2 and 1 (each within the scatter of the next).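

In this assay, among these compounds, hydroxy to methoxy at the end of the saturated chain gives a 5.8-fold lower number from compound 1 to compound 3 (0.77 log units; beyond the scatter) and is the first step that differs in one place. It shows that this oxygen is not a silent position in this assay: methyl in place of hydrogen on an oxygen on a saturated carbon moves the number beyond the scatter, although only one heavy atom enters and the rest of compound 1 stays unchanged. This rests on a single pair, so it describes this change on this core and is no general pattern, and no measurement at hand bears on what lies behind the step.

From the compounds shown here alone, it remains open whether other groups in this place, such as an ethoxy, an amine or a carboxylic acid, would give a step of similar size, or whether a shorter or longer chain would alter it. Also open, going by these compounds, is whether 2-hydroxyethyl to 2-methoxyethyl on the core of compound 2 would repeat the step.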